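The source may hold more compounds than are shown below. What is called first, only, known or untested is meant among the compounds shown, and "the series" means these compounds.

Measured so far in an assay on CHO cells for displacement of a labelled ligand from Substance-P receptor (Homo sapiens); on this read-out lower numbers stand for stronger inhibition and higher numbers for weaker inhibition:
compound 1 `C[C@@H](O[C@H]1CN2C(=O)C=C(c3ccc(F)cc3)CC2[C@@H]1c1ccc(F)cc1)c1cc(C(F)(F)F)cc(C(F)(F)F)c1`: 2 nM
compound 2 `C[C@@H](O[C@H]1CN2C(=O)C=C(c3ccncc3)CC2[C@@H]1c1ccc(F)cc1)c1cc(C(F)(F)F)cc(C(F)(F)F)c1`: 0.14 nM
compound 3 `C[C@@H](O[C@H]1CN2C(=O)C=C(c3cnn(C)c3)CC2[C@@H]1c1ccc(F)cc1)c1cc(C(F)(F)F)cc(C(F)(F)F)c1`: 0.13 nM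

Compound 1 stands highest of the three numbers. Its nearest neighbour is compound 2, reached through a 14-fold lower number from compound 1 to compound 2 (1.15 log units; beyond the scatter), and its furthest is compound 3, reached through a 15-fold lower number from compound 1 to compound 3 (1.19 log units; beyond the scatter). Between the two lower compounds the step is a 1.1-fold lower number from compound 2 to compound 3 (0.03 log units; within the scatter).

Compound 4 `C[C@@H](O[C@H]1CN2C(=O)C=C(C3=CCC(O)CC3)CC2[C@@H]1c1ccc(F)cc1)c1cc(C(F)(F)F)cc(C(F)(F)F)c1` has not yet been measured in this assay. It differs from compound 1 in one place: 4-hydroxycyclohex-1-en-1-yl in place of 4-fluorophenyl on a double-bonded ring carbon. Both measured steps away from compound 1 bear on this change, since each replaces the same 4-fluorophenyl group on the same double-bonded ring carbon, and both gave large steps to lower numbers. In both of those cases, however, the entering group was an aromatic ring carrying a hydrogen-bond acceptor. The 4-hydroxycyclohex-1-en-1-yl group is non-aromatic and brings one donor together with one acceptor, a combination without precedent among the three measured compounds, so the step cannot be read directly from them. A step to a lower number, smaller than the two measured ones, is expected: a 2.5-fold lower number from compound 1 to compound 4 (0.40 log units; beyond the scatter). For compound 4 the estimate is 0.8 nM, with a range from 0.15 nM to 4 nM.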

Compound 4, half-maximal inhibitory concentration: 0.18 nM
Compound 4: middle estimate off by 4.4-fold (0.65 log units), on the high side; the measured number falls inside the stated range.
By their numbers in this assay, from the lowest: compounds 3, 2 and 4 (each within the scatter of the next); then compound 1.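

In this assay the large step of an 11-fold lower number from compound 1 to compound 4 (1.05 log units; beyond the scatter) shows that, at this double-bonded ring carbon, the drop from compound 1 does not depend on an aromatic entering ring, since 4-hydroxycyclohex-1-en-1-yl is a non-aromatic ring of carbon only. The three replacements stay level, as both a 1.4-fold higher number from compound 3 to compound 4 (0.14 log units; within the scatter) and a 1.3-fold higher number from compound 2 to compound 4 (0.11 log units; within the scatter) lie within the scatter, so among the four compounds only compound 1 stands apart. No evidence is at hand to explain why the 4-fluorophenyl compound separates from the other three.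

Open, from the compounds shown here alone, is whether the hydroxyl of compound 4 contributes at all, a question that plain cyclohex-1-en-1-yl would settle. Also open, going by these compounds, is how an amine or a carboxylic acid in place of that hydroxyl would compare.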